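A few compounds are considered here, and "the series" means these few. Any claim that something is new, unique, unknown or untested is made for them only; others in the source may bear on it.

In a functional assay on A-375 cells (Homo sapiens) for antiproliferative activity, read by MTT assay, with a stated time of 24 h, tested at 33.33 ug/mL (on this read-out higher numbers stand for a stronger effect at the one concentration tested and lower numbers for a weaker effect), compound 2 `Cc1c(C(=O)Nc2c(F)cc(-c3cccc(F)c3)cc2F)nc2ccc(F)cc2c1C(=O)O` gives 41.3%, the smaller of the two numbers shown, while compound 1 `CCc1ccc2nc(C(=O)Nc3c(F)cc(-c4cccc(F)c4)cc3F)c(C)c(C(=O)O)c2c1` gives 47.1%; the gap between them lies within the scatter. Compound 3 `Cc1c(C(=O)Nc2c(F)cc(-c3cccc(F)c3)cc2F)nc2ccc(C(F)(F)F)cc2c1C(=O)O` differs from compound 2 by trifluoromethyl in place of fluoro on an aromatic carbon. Going by the values given here, the one measured step that bears on this position, a number 5.8 percentage points lower from compound 1 to compound 2 (within the scatter), was a small one, so no step beyond the scatter is expected in this assay. Compound 3 is therefore expected to give 44%, between 30% and 58%. Compound 3 would then show an expected step of a number 2.7 percentage points higher from compound 2 to compound 3 (within the scatter).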

Compound 3, a percentage reported as inhibition, at one concentration (the size of the read-out at that concentration, not a potency): 51%
Estimate against measurement, compound 3: 7 percentage points below; the measured number falls inside the stated range.
By their numbers in this assay, from the lowest: compounds 2, 1 and 3 (each within the scatter of the next).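

In this assay trifluoromethyl in place of fluoro gives a number 9.7 percentage points higher from compound 2 to compound 3 (within the scatter) and trifluoromethyl in place of ethyl gives a number 3.9 percentage points higher from compound 1 to compound 3 (within the scatter) so a third group at this position, with four heavy atoms, also brings no change beyond the scatter. Ethyl, fluoro and trifluoromethyl therefore cannot be ranked on these numbers. Nothing given here explains these results. From the compounds shown here alone, whether an amine, a carboxylic acid or a longer chain at this position would move the number beyond the scatter remains open.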